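A few compounds are considered here, and "the series" means these few. Any claim that something is new, unique, unknown or untested is made for them only; others in the source may bear on it.

Among the measured compounds shown here, compound 1, `Cc1cc(OCCCN2CCCC2=O)cc(C)c1-c1cccc(COc2ccc3c(c2)OC[C@H]3CC(=O)O)c1`, is one of two compounds measured in an assay on CHO cells for displacement of a labelled ligand from Free fatty acid receptor 1 (Homo sapiens), read by scintillation counting, with a stated time of 90 min, in the presence of a further agent that is not named here; a lower number here means a stronger inhibitor, a higher number a weaker inhibitor; in this assay compound 1 gives 31 nM. The other is compound 2, `Cc1c(C)c(-c2cccc(COc3ccc4c(c3)OC[C@H]4CC(=O)O)c2)c(C)c(C)c1OC1CCS(=O)(=O)CC1`, which in this assay gives 40 nM; the two numbers lie within the scatter of each other, so neither can be ranked above the other. The unmeasured compound 3, `CCS(=O)(=O)CCOc1cc(C)c(-c2cccc(COc3ccc4c(c3)OC[C@H]4CC(=O)O)c2)c(C)c1`, differs from compound 1 in one place: ethylsulfonyl in place of (2-oxopyrrolidin-1-yl)methyl on a saturated chain carbon, two bonds along the chain from an oxygen on an aromatic ring. Compound 2 carries a sulfone-bearing tail on its own core and shows that such a tail is compatible with binding at the level of 40 nM, so no large step is expected from compound 1 to compound 3. The step from compound 1 to compound 3 is expected to be a 1.3-fold higher number from compound 1 to compound 3 (0.11 log units; within the scatter), a change not beyond the scatter. Compound 3 is therefore estimated at 40 nM, with a range from 15 nM to 110 nM.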

Compound 3, inhibition constant: 37 nM
Beside the measured number, compound 3's estimate is 1.1-fold (0.03 log units) above it, within the range that was stated.
By their numbers in this assay, from the lowest: compounds 1, 3 and 2 (each within the scatter of the next).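

On the shared core, the change is a 1.2-fold higher number from compound 1 to compound 3 (0.08 log units; within the scatter) in this assay, so ethylsulfonyl and (2-oxopyrrolidin-1-yl)methyl cannot be told apart at this place, on a saturated chain carbon, two bonds along the chain from an oxygen on an aromatic ring. This is the first pair shown that differs in one place, and it gives a direct reading that the earlier compounds could not: the group that leaves holds a five-membered non-aromatic ring, the group that enters holds no ring, and the numbers stay within the scatter. Nothing available explains this result.

As far as these compounds go, what an amine or a carboxylic acid at this place would do stays open, as does the effect of a longer chain carrying the ethylsulfonyl group. From the compounds shown here alone, whether the same change reads alike on another core also stays open.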